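A few compounds are considered here, and "the series" means these few. Any claim that something is new, unique, unknown or untested is made for them only; others in the source may bear on it.

In a functional assay on HL-60 cells (Homo sapiens) for cytotoxicity, read by MTT assay, with a stated time of 3 days (on this read-out higher numbers stand for weaker inhibition and lower numbers for stronger inhibition), compound 1 `N#Cc1c(-c2ccccc2)nc(SCc2nc3ccccc3[nH]2)nc1N1CCNCC1` gives 4 nM and compound 2 `CN1CCN(c2nc(SCc3nc4ccccc4[nH]3)nc(-c3ccccc3)c2C#N)CC1` gives 2.8 nM on the same read-out. Compound 2 therefore stands level with compound 1 within the scatter, and the series offers no other measured number. Compound 3 `N#Cc1c(-c2ccccc2)nc(SCc2nc3ccccc3[nH]2)nc1N1CCN(S(=O)(=O)c2ccccc2)CC1` carries phenylsulfonyl in place of methyl on an amine nitrogen in a ring, counted as phenylsulfonyl in place of methyl on an amine nitrogen in a ring for this change. Going by the values given here, the only measured step at that place is a 1.4-fold lower number from compound 1 to compound 2 (0.15 log units; within the scatter) and it exchanges hydrogen for methyl only. That small step gives little guidance for a group as large as phenylsulfonyl, so any forecast in this assay is uncertain. A move towards a higher number is expected, on weak grounds. The estimated step is a 5.4-fold higher number from compound 2 to compound 3 (0.73 log units; beyond the scatter) with wide uncertainty. Compound 3 is estimated at 15 nM with an expected range of 2 nM to 120 nM in this assay series.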

Compound 3, half-maximal inhibitory concentration: 4.23 nM
Compound 3: the middle estimate sits 3.5-fold (0.55 log units) above what was measured; measured number inside the range.
By their numbers in this assay, from the lowest: compounds 2, 1 and 3 (each within the scatter of the next).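

In this assay, putting phenylsulfonyl on the amine nitrogen of the six-membered ring gives a 1.5-fold higher number from compound 2 to compound 3 (0.18 log units; within the scatter) and a 1.1-fold higher number from compound 1 to compound 3 (0.02 log units; within the scatter). Earlier, this position had been read only with hydrogen and methyl; the new steps extend the level result to a group of 9 heavy atoms that brings a six-membered aromatic ring and 2 hydrogen-bond acceptors, so hydrogen, methyl and phenylsulfonyl all stand within the scatter of one another in compounds 1, 2 and 3. No supporting data are available to account for this result.

Still open, going by these compounds, is whether an acetyl group, a longer chain or a carboxylic acid on this nitrogen would also stay level in this assay. Also open, on these data alone, is whether the level result would hold if the nitrile on the shared core were replaced by an amide.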